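A few compounds are considered here, and "the series" means these few. Any claim that something is new, unique, unknown or untested is made for them only; others in the source may bear on it.

Compound 1 `CC(C)c1cccc(NC(=O)CCc2cccc3c2B(O)OC3)c1`: 22000 nM
Compound 2 `O=C(CCc1cccc2c1B(O)OC2)Nc1cccc(-c2ccccc2)c1`: 12000 nM
Compound 3 `O=C(CCc1cccc2c1B(O)OC2)Nc1cccc(-c2ccc(F)cc2)c1`: 4100 nM

These numbers come from an ADME assay on WI-38 cells (Homo sapiens) for cytotoxicity, read by MTT assay, with a stated time of 72 h; on this read-out lower numbers stand for stronger inhibition and higher numbers for weaker inhibition. Compound 3 has the lowest number of the three, and its gaps to the other two lie beyond the scatter. The next compound, compound 4 `O=C(CCc1cccc2c1B(O)OC2)Nc1cccc(-c2cccc(Cl)c2)c1`, carries 3-chlorophenyl in place of 4-fluorophenyl on an aromatic carbon.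

Among the measured compounds shown here, three measured steps bear on this change. Phenyl in place of isopropyl gave a 1.8-fold lower number from compound 1 to compound 2 (0.26 log units; within the scatter), and 4-fluorophenyl in place of isopropyl gave a 5.4-fold lower number from compound 1 to compound 3 (0.73 log units; beyond the scatter). For the measured compounds named here, the closest precedent is fluoro in place of hydrogen on an aromatic carbon, which gave a 2.9-fold lower number from compound 2 to compound 3 (0.47 log units; beyond the scatter), a modest step. Going by the values given here, that is the only measured step that adds a halogen, and no measured compound contains chlorine. The data therefore give no firm direction for this swap. Compound 4 keeps a halogen on its added phenyl ring, as compound 3 does, so no shift beyond the scatter is expected in this assay. The estimated change is a 1.1-fold higher number from compound 3 to compound 4 (0.04 log units; within the scatter). For compound 4 the expected value is 4500 nM, with an estimated range from 1800 nM to 11000 nM.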

Compound 4, half-maximal inhibitory concentration: 58000 nM
The estimate for compound 4 lay 13-fold (1.11 log units) below the measured number; the measured number lies above the stated range.
By their numbers in this assay, from the lowest: compound 3; then compounds 2 and 1 (each within the scatter of the next); then compound 4.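

In this assay, an added aromatic ring no longer goes with a lower number at this position: 3-chlorophenyl in place of isopropyl gives a 2.6-fold higher number from compound 1 to compound 4 (0.42 log units; beyond the scatter), the opposite direction from the two earlier replacements of isopropyl. A halogen on that ring also has no single direction, as fluoro in place of hydrogen gave a 2.9-fold lower number from compound 2 to compound 3 (0.47 log units; beyond the scatter), while chloro in place of hydrogen gives a 4.8-fold higher number from compound 2 to compound 4 (0.68 log units; beyond the scatter), and the direct swap between the two halogen-bearing rings gives a 14-fold higher number from compound 3 to compound 4 (1.15 log units; beyond the scatter), a large step between groups with the same count of heavy atoms. Nothing available here explains why these two closely matched groups end up so far apart.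

Compound 3 and compound 4 differ both in which halogen the ring carries and in where it sits on that ring, so the compounds shown cannot tell which of these two differences matters, or whether both do. From the compounds shown here alone, it also remains open whether a methoxy group or an amine on the same ring would give a number closer to that of compound 3 or to that of compound 4.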